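Shortening the Amide Substituent to 1-Carboxyethyl

The compounds below may be only part of what the source reports. "The series", "measured", "known", "first", "only" and "open" are said of these compounds alone.

compound 1 `CCn1c(C(=O)N(CCC#N)CCC#N)ccc1C(CC)(CC)c1ccc(OCCC(O)(CC)CC)c(C)c1`: > 10000 nM
compound 2 `CCC(C)C(NC(=O)c1ccc(C(CC)(CC)c2ccc(OCCC(O)(CC)CC)c(C)c2)n1CC)C(=O)OC`: > 10000 nM

In an assay on cells for agonist activity at vitamin D3 receptor (Homo sapiens), with a stated time of 96 h (on this read-out higher numbers stand for an effect only at larger amounts of compound and lower numbers for an effect already at smaller amounts), compound 1 gives > 10000 nM, which is a limit of the assay and not a number. In the same assay compound 2 gives > 10000 nM, again a limit. The step that the two limits leave unreadable from compound 1 to compound 2 therefore cannot be read, since both values sit at the limit of > 10000 nM in this assay, at which 2 of the 2 values shown sit. Compound 3 `CCn1c(C(=O)NC(C)C(=O)O)ccc1C(CC)(CC)c1ccc(OCCC(O)(CC)CC)c(C)c1` differs from compound 2 by a group of 5 heavy atoms (3 carbon, 2 oxygen; no ring) in place of a group of 9 heavy atoms (7 carbon, 2 oxygen; no ring), on an amide-type nitrogen. Within the data shown here, no measured step bears on this change, and compound 2 stands only at a limit. For the step of a number no higher from compound 2 to compound 3 (the limit leaves the size open) no movement beyond the scatter is expected. Compound 3 is estimated to give 10000 nM, in the range 3000 nM to 30000 nM.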

Compound 3, half-maximal effective concentration: 66 nM
Beside the measured number, compound 3's estimate is 150-fold (2.18 log units) above it; measured number outside the range, below it.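

In this assay, the group on the amide-type nitrogen turns out to matter, which the earlier pair could not show: 1-carboxyethyl there brings an at least 150-fold lower number from compound 2 to compound 3 (2.18 log units; beyond the scatter), and the change on the carbonyl carbon brings an at least 150-fold lower number from compound 1 to compound 3 (2.18 log units; beyond the scatter). Both steps start from a limit of the assay, so neither has a fixed size: the limit of > 10000 nM in this assay, at which 2 of the 3 values shown sit.

The compounds shown leave open whether the carboxylic acid or the shorter chain carries the gain, as compound 3 changes both at once; the methyl ester of 1-carboxyethyl, or a longer chain ending in a carboxylic acid, would separate them. As far as these compounds go, whether an amine in place of the acid would serve also stays open.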